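The source may hold more compounds than are shown below. What is called first, only, known or untested is meant among the compounds shown, and "the series" means these compounds.

Compound 3 `Cc1ccc2[nH]c(=O)c(CN(Cc3ccc(C(C)(C)C)cc3)[C@@H](C)c3ccc(F)cc3)cc2c1` shares its core with compound 1 `Cc1ccc2[nH]c(=O)c(CN(Cc3ccccc3)Cc3ccc(C(C)(C)C)cc3)cc2c1` and compound 2 `Cc1ccc2[nH]c(=O)c(CN(Cc3ccc(OC(F)(F)F)cc3)Cc3ccc(C(C)(C)C)cc3)cc2c1` and differs from both only in the group on the amine nitrogen. In a toxicity assay on MDCK cells (Canis lupus familiaris) for cytotoxicity, read by crystal violet staining, with a stated time of 48 h (on this read-out lower numbers stand for higher toxicity in this test and higher numbers for lower toxicity in this test), compound 3 gives > 5000 nM, which is a limit of the assay and not a number. In this assay compound 1 gives > 5000 nM, likewise a limit. In this assay compound 2 gives > 5000 nM, again a limit. So (the limit of > 5000 nM in this assay, at which 3 of the 3 values shown sit), and the steps a step that the two limits leave unreadable from compound 1 to compound 3 and a step that the two limits leave unreadable from compound 2 to compound 3, both at that amine nitrogen, cannot be sized, just as the step that the two limits leave unreadable from compound 1 to compound 2 cannot. Compound 4 `Cc1ccc2[nH]c(=O)c(CN(Cc3ccc(C(C)(C)C)cc3)C(C)c3ccc(N(C)C)c(Cl)c3)cc2c1` carries the next change at the same place: 1-(3-chloro-4-(dimethylamino)phenyl)ethyl in place of 1-(4-fluorophenyl)ethyl on an amine nitrogen. Among the compounds with values here, since no measured step at this nitrogen reads as a change in this assay, nothing points to a step beyond the scatter here. Compound 4 is therefore expected to sit at 7000 nM, within 2500 nM to 20000 nM, most probably again as a limit. This amounts to an expected step that the limit leaves unreadable from compound 3 to compound 4.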

Compound 4, half-maximal cytotoxic concentration: 9800 nM
Estimate against measurement, compound 4: 1.4-fold (0.15 log units) below, and the stated range covers the measured number.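

Compound 4 has a measured number in this assay, but its steps from compound 1, compound 2 and compound 3 cannot be read, since those three compounds give only a limit: the limit of > 5000 nM in this assay, at which 3 of the 4 values shown sit.

The compounds shown leave open whether 1-(3-chloro-4-(dimethylamino)phenyl)ethyl on the amine nitrogen changes the read-out at all.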